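Benzoyl in place of acetyl on the shared core

This account rests on a few compounds, and the source may have more. Where it says the series, first, only, none or still open, it means among the compounds named here.

Measured so far in a physicochemical assay for metabolic stability, read by HPLC, in phosphate buffer, at pH 7.7; on this read-out lower numbers stand for a shorter-lived compound and higher numbers for a longer-lived compound:
Compound 1, `CCC(=O)N[C@@H](C)C(=O)N(C)/N=N/c1ccc(C#N)cc1`: 10.1 h
Compound 2, `CCCC(=O)N[C@@H](C)C(=O)N(C)/N=N/c1ccc(C#N)cc1`: 9.1 h
Compound 3, `CC(=O)N[C@@H](C)C(=O)N(C)/N=N/c1ccc(C#N)cc1`: 9.8 h

Compound 3 stands within the scatter of both other compounds: the step of a 1.0-fold lower number from compound 1 to compound 3 (0.01 log units; within the scatter) and the step of a 1.1-fold higher number from compound 2 to compound 3 (0.03 log units; within the scatter) are each too small to separate it from compound 1 or compound 2. Compound 4, `C[C@H](NC(=O)c1ccccc1)C(=O)N(C)/N=N/c1ccc(C#N)cc1`, differs from compound 3 by phenyl in place of methyl on a carbonyl carbon.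

Going by the values given here, three measured steps bear on this change, all of them varying the saturated chain on the same carbonyl carbon: a 1.1-fold lower number from compound 1 to compound 2 (0.05 log units; within the scatter), a 1.0-fold lower number from compound 1 to compound 3 (0.01 log units; within the scatter) and a 1.1-fold higher number from compound 2 to compound 3 (0.03 log units; within the scatter). None of them introduces an aromatic ring, so they speak to the change only indirectly, by showing that variation of this acyl group has so far left the half-life unchanged. The expectation for compound 4 in this assay is therefore no step beyond the scatter, with wider uncertainty than the measured steps carry, since a phenyl is a larger change than any of them. Compound 4 is estimated at 10 h, in a range from 5 h to 20 h. That estimate means an expected step of a 1.0-fold higher number from compound 3 to compound 4 (0.01 log units; within the scatter).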

Compound 4, half-life: 9.2 h
Compound 4: middle estimate off by 1.1-fold (0.04 log units), on the high side; the measured number falls inside the stated range.
By their numbers in this assay, from the lowest: compounds 2, 4, 3 and 1 (each within the scatter of the next).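

In this assay, an aromatic ring on this carbonyl carbon proves no different from a saturated chain: phenyl stays within the scatter of methyl (a 1.1-fold lower number from compound 3 to compound 4 (0.03 log units; within the scatter)), of propyl (a 1.0-fold higher number from compound 2 to compound 4 (0.00 log units; within the scatter)) and of ethyl (a 1.1-fold lower number from compound 1 to compound 4 (0.04 log units; within the scatter)). The earlier compounds shown here had varied only saturated chains here, whereas compound 4 extends the same flat picture from acetyl to benzoyl, and none of the four compounds goes against it. Nothing measured here speaks to why the half-life does not separate these acyl groups.

Left open is whether an acyl group bearing an amine or a carboxylic acid, rather than carbon alone, would also stay within the scatter in this assay. Also open, on these data alone, is whether changes elsewhere on the shared core would be as silent.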